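The source may hold more compounds than are shown below. What is called first, only, known or untested is meant among the compounds shown, and "the series" means these compounds.

In a functional assay on MCF-10A cells (Homo sapiens) for antiproliferative activity, with a stated time of 48 h (a higher number here means that more compound is needed for the effect, a lower number that less compound is needed), compound 1 `COc1ccc2nc(C)cc(NCc3ccccc3)c2c1` gives 28600 nM. Going by the values given here, compound 2 `COc1ccc2nc(C)cc(NCc3ccc(C(C)(C)C)cc3)c2c1` gives 7000 nM, the lower of the two numbers measured so far. Compound 3 `COc1ccc(CNc2cc(C)nc3ccc(OC)cc23)cc1` keeps the shared core and changes one place, with methoxy in place of tert-butyl on an aromatic carbon, para to a large group: methoxy in place of tert-butyl on an aromatic carbon. Among the compounds with values here, only one measured step bears on this change, and it concerns the same carbon: a 4.1-fold lower number from compound 1 to compound 2 (0.61 log units; beyond the scatter), a modest step beyond the scatter. Within the data shown here, no measured compound carries methoxy, so the data give only two reference points at this carbon. With hydrogen there, compound 1 stands at 28600 nM, and with tert-butyl, compound 2 stands at 7000 nM. Losing the tert-butyl may therefore give back part of that gain, placing compound 3 somewhere between the two, though this is an expectation drawn from a single step. The expected change, toward a higher number, is a 2.0-fold higher number from compound 2 to compound 3 (0.30 log units; within the scatter). The estimate for compound 3 is 14000 nM, with an expected range from 6000 nM to 32000 nM.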

Compound 3, half-maximal effective concentration: 9700 nM
For compound 3 the middle estimate is 1.4-fold (0.16 log units) above the measured one; low and high end bracket the measured number.
By their numbers in this assay, from the lowest: compounds 2 and 3 (each within the scatter of the next); then compound 1.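

this assay The step of a 1.4-fold higher number from compound 2 to compound 3 (0.14 log units; within the scatter) stays within the scatter, so tert-butyl and methoxy cannot be told apart at this carbon, even though tert-butyl has 4 heavy atoms, all carbon, and methoxy has 2 heavy atoms, one of them an oxygen that counts as a hydrogen-bond acceptor. Measured against hydrogen, the step of a 2.9-fold lower number from compound 1 to compound 3 (0.47 log units; beyond the scatter) lies beyond the scatter, so among these three compounds the lower number seen earlier with tert-butyl is no longer tied to that one group: both groups at this carbon give a lower number than hydrogen does. Nothing available here explains why two such different groups read alike.

As far as these compounds go, what remains open is whether other groups at this same carbon, such as a chlorine atom, a hydroxyl, an amine or a carboxylic acid, would also give a number lower than that of compound 1. From the compounds shown here alone, it is also open whether a step larger than these modest ones can be reached from this carbon, or whether that would take a change elsewhere on the shared core.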